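The source may hold more compounds than are shown below. What is called first, only, known or untested is meant among the compounds shown, and "the series" means these compounds.

In an in vitro ADME assay on microsomes from liver (Rattus norvegicus) for metabolic stability, tested at 5 uM (on this read-out lower numbers stand for a shorter-lived compound and higher numbers for a longer-lived compound), compound 3 `C=CC(=O)NCc1coc(-c2c(N)ncnc2Nc2ccc(F)c(Cl)c2)n1` gives 0.4 h, which places it second highest of the three measured numbers. Compound 2 `C=CC(=O)NCc1coc(-c2c(N)ncnc2Nc2ccc(Oc3ccccn3)c(Cl)c2)n1` gives 0.267 h, and the step of a 1.5-fold higher number from compound 2 to compound 3 (0.18 log units; within the scatter) lies within the scatter. Compound 1 `C=CC(=O)NCc1coc(-c2c(N)ncnc2Nc2ccc(Oc3ccccc3)c(Cl)c2)n1` gives 0.983 h, and the step of a 2.5-fold lower number from compound 1 to compound 3 (0.39 log units; beyond the scatter) lies beyond it, as does a 3.7-fold lower number from compound 1 to compound 2 (0.57 log units; beyond the scatter). Compound 4 `C=CC(=O)NCc1coc(-c2c(N)ncnc2Nc2ccc(Cl)c(Cl)c2F)n1` differs from compound 3 in one place: 3,4-dichloro-2-fluorophenyl in place of 3-chloro-4-fluorophenyl on a nitrogen on an aromatic ring. Within the data shown here, no measured step makes this exact change; the two measured steps that reach compound 3 altered the same ring and were modest or within the scatter. Compound 4 is therefore expected to keep a similar half-life, with no change at the digits printed from compound 3 to compound 4 (within the scatter) in this assay, estimated at 0.4 h, between 0.2 h and 0.8 h.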

Compound 4, half-life: > 1.66 h
Compound 4 ended at the assay's limit; the forecaster's own chance of this, stated with the estimate: 5%; middle value at least 4.1-fold (0.61 log units) away from the limit.
By their numbers in this assay, from the lowest: compounds 2 and 3 (each within the scatter of the next); then compound 1. At a limit, above all of these: compound 4.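

In this assay, the ring on the nitrogen proves able to move the half-life upward: 3,4-dichloro-2-fluorophenyl in place of 3-chloro-4-fluorophenyl gives an at least 4.1-fold higher number from compound 3 to compound 4 (0.61 log units; beyond the scatter). The earlier steps from compound 1 only lowered the number or stayed within the scatter, so this is the first listed change on this ring to raise it beyond the scatter. Compound 4 stands at a limit of the assay, so its step is a minimum: the limit of > 1.66 h in this assay, at which 1 of the 4 values shown sits.

The compounds shown leave open how much of the step belongs to the added chlorine and how much to the new place of the fluorine. They also leave open whether a methyl or methoxy group in place of that chlorine would act the same way.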